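A Branched Chain Replaces Propyl on the Shared Core

The compounds below may be only part of what the source reports. "The series", "measured", "known", "first", "only" and "open" are said of these compounds alone.

The three compounds measured in an in vitro functional assay on cells for agonist activity at Bombesin receptor subtype-3 (Mus musculus), read by luminescence and calcium flux (on this read-out lower numbers stand for an effect already at smaller amounts and higher numbers for an effect only at larger amounts of compound), are:

Compound 1 `O=C(O)c1ccccc1-c1ccc(CCc2ncc(CC3CCCCC3)[nH]2)cc1`: 7.3 nM
Compound 2 `O=C(O)c1ccccc1-c1ccc(CCc2ncc(Cc3ccc(Cl)cc3)[nH]2)cc1`: 102 nM
Compound 3 `CCCCc1cnc(CCc2ccc(-c3ccccc3C(=O)O)cc2)[nH]1`: 93 nM

Compound 3 stands second highest of the three numbers. Its nearest neighbour is compound 2, whose number lies within the scatter of compound 3, as the step of a 1.1-fold lower number from compound 2 to compound 3 (0.04 log units; within the scatter) shows. The furthest is compound 1, and the step of a 13-fold higher number from compound 1 to compound 3 (1.11 log units; beyond the scatter) is large and beyond the scatter. Compound 2 shows the matching step a 14-fold higher number from compound 1 to compound 2 (1.15 log units; beyond the scatter), so on the saturated chain carbon bound to an aromatic carbon both the smaller propyl and the 4-chlorophenyl give a clearly higher number than cyclohexyl.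

Compound 4 `CCC(C)(CC)Cc1cnc(CCc2ccc(-c3ccccc3C(=O)O)cc2)[nH]1` has not been measured. It differs from compound 3 by 1-ethyl-1-methylpropyl in place of propyl on a saturated chain carbon bound to an aromatic carbon. Among the measured compounds shown here, the entering group is larger than propyl and closer in size to the cyclohexyl of compound 1, the only bulky saturated group measured, which gave the lowest number. For the measured compounds named here, no measured step covers a branched open chain at this place, so the expectation rests on compound 1 alone. The step of a 3.7-fold lower number from compound 3 to compound 4 (0.57 log units; beyond the scatter) is expected to lower the number, though probably not all the way to compound 1. Compound 4 is estimated at 25 nM, within the range 7 nM to 90 nM.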

Compound 4, half-maximal effective concentration: 30 nM
Compound 4: the middle estimate sits 1.2-fold (0.08 log units) below what was measured, within the range that was stated.
By their numbers in this assay, from the lowest: compound 1; then compound 4; then compounds 3 and 2 (each within the scatter of the next).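

In this assay the change to 1-ethyl-1-methylpropyl on a saturated chain carbon bound to an aromatic carbon gives (a 3.1-fold lower number from compound 3 to compound 4 (0.49 log units; beyond the scatter)) and, against the 4-chlorophenyl group, (a 3.4-fold lower number from compound 2 to compound 4 (0.53 log units; beyond the scatter)), so this is the first open chain shown to bring the number below the level shared by compound 2 and compound 3. A ring at this place is therefore not needed for a lower number, yet the branched chain does not match the cyclohexyl group, as the step (a 4.1-fold higher number from compound 1 to compound 4 (0.61 log units; beyond the scatter)) shows. Among the saturated groups at this place, propyl, 1-ethyl-1-methylpropyl and cyclohexyl now give three numbers that each lie beyond the scatter of the others.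

Still open, going by these compounds, is how a cyclopentyl group, an unbranched hexyl chain, or a chain ending in a hydroxyl group or an amine would compare at this place. The compounds shown also give no measured reason for the differences among these groups.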